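The compounds below may be only part of what the source reports. "The series", "measured", "known", "first", "only" and "open" are said of these compounds alone.

Measured so far:
- compound 1, `CCCSc1nc(N/N=C(\C)c2ccccc2O)c2nnn(Cc3cccc(Cl)c3)c2n1`: 13000 nM
- compound 2, `CCCSc1nc(N/N=C/c2ccc3ccccc3c2)c2nnn(Cc3ccccc3)c2n1`: > 64000 nM

Both were tested in a functional assay on ECa-109 cells (Homo sapiens) for antiproliferative activity, read by MTT assay, with a stated time of 72 h; on this read-out lower numbers stand for stronger inhibition and higher numbers for weaker inhibition. Among the measured compounds shown here, compound 1 gives 13000 nM and is the only compound with an actual number in this assay. Compound 2 gives > 64000 nM, which is a limit of the assay rather than a number, as noted in the limit of > 64000 nM in this assay, at which 1 of the 2 values shown sits. Compound 1 therefore stands alone as the single measured point from which the next compound is judged.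

Compound 3, `CCCSc1nc(N/N=C(\C)c2ccccc2O)c2nnn(Cc3ccc(Cl)cc3)c2n1`, has not yet been measured. It shares its atoms with compound 1, joined differently: 4-chlorophenyl in place of 3-chlorophenyl on a saturated chain carbon bound to an aromatic nitrogen. The rest of the molecule is unchanged.

For the measured compounds named here, because no pair of measured compounds differs in a single place, no measured step exists to set the expected size of this change. Moving a chlorine from one position of the ring to another is a small rearrangement, and the expected step from compound 1 to compound 3 is no change at the digits printed from compound 1 to compound 3 (within the scatter), which is within the usual scatter in either direction. Compound 3 is therefore estimated at 13000 nM, in a range from 5000 nM to 35000 nM.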

Compound 3, half-maximal inhibitory concentration: 11200 nM
Compound 3: the middle estimate sits 1.2-fold (0.06 log units) above what was measured; low and high end bracket the measured number.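

In this assay, among the compounds shown here, the change from 3-chlorobenzyl to 4-chlorobenzyl gives a 1.2-fold lower number from compound 1 to compound 3 (0.06 log units; within the scatter), and this is the first measured step in which only one place in the molecule differs. Compound 1 on its own could say nothing about where the chlorine sits on this ring, whereas this pair shows that these two placings cannot be told apart in this read-out, with the rest of the molecule held constant. Nothing measured here bears on why the two placings read alike.

The pair leaves open whether a different group in place of the chlorine, such as a methoxy group, an amine or a carboxylic acid, would shift the number beyond the scatter, since only chlorine has been compared at this position. Compound 2 differs from compound 1 in more than one place, and it offers no comparison for this question. Compound 2 gives > 64000 nM, a limit of the assay.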